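The compounds below may be only part of what the source reports. "The series", "measured", "known", "first", "only" and "open" are said of these compounds alone.

Working notes on the series.

Among the compounds with values here, compound 3 `CN(C(=O)NC(=O)c1c(F)cccc1F)c1nc(C(F)(F)F)c(C(=O)N/N=C/c2ccc(C(F)(F)F)cc2)s1` gives 40.1 ug/mL in a functional assay on A549 cells (Homo sapiens) for inhibition, read by MTT assay, with a stated time of 72 h (a lower number here means a stronger inhibitor, a higher number a weaker inhibitor), the highest of the three numbers measured so far. Compound 1 `Cc1nc(N(C)C(=O)NC(=O)c2c(F)cccc2F)sc1C(=O)N/N=C/c1cccc(C(F)(F)F)c1` stands closest, giving 30.3 ug/mL, a gap within the scatter; compound 2 `Cc1nc(N(C)C(=O)NC(=O)c2c(F)cccc2F)sc1C(=O)N/N=C/c1ccccc1C(F)(F)F` stands furthest, giving 5.43 ug/mL. Within the data shown here, the one single-point step measured so far, a 5.6-fold lower number from compound 1 to compound 2 (0.75 log units; beyond the scatter), concerns the aryl group on the carbon double-bonded to nitrogen and is modest but beyond the scatter.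

Compound 4 `Cc1nc(N(C)C(=O)NC(=O)c2c(F)cccc2F)sc1C(=O)N/N=C/c1ccc(C(F)(F)F)cc1` has not been measured. It differs from compound 3 by methyl in place of trifluoromethyl on an aromatic carbon of the core. Among the measured compounds shown here, no measured step touches this position, so the step from compound 1 to compound 2 does not bear on it directly; it only shows that the aryl substitution pattern, which compound 4 keeps from compound 3, moves the number. Compound 1 and compound 2 both carry the methyl that enters in compound 4, and their numbers bracket a wide range. With nothing to anchor the change, no step beyond the scatter is expected, a 1.1-fold lower number from compound 3 to compound 4 (0.06 log units; within the scatter). Compound 4 is estimated at 35 ug/mL, expected between 12 ug/mL and 100 ug/mL.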

Compound 4, half-maximal inhibitory concentration: 60.5 ug/mL
Beside the measured number, compound 4's estimate is 1.7-fold (0.24 log units) below it, within the range that was stated.
By their numbers in this assay, from the lowest: compound 2; then compounds 1, 3 and 4 (each within the scatter of the next).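

In this assay, the swap of trifluoromethyl for methyl on the aromatic carbon next to the ring nitrogen of the shared core gives no step beyond the scatter (a 1.5-fold higher number from compound 3 to compound 4 (0.18 log units; within the scatter)). With methyl held on the core, the aryl group can now be read at three placements: 4-(trifluoromethyl)phenyl separates clearly from 2-(trifluoromethyl)phenyl (an 11-fold higher number from compound 2 to compound 4 (1.05 log units; beyond the scatter)) but not from 3-(trifluoromethyl)phenyl (a 2.0-fold higher number from compound 1 to compound 4 (0.30 log units; within the scatter)). No evidence to hand accounts for these results.

The compounds shown carry only methyl and trifluoromethyl at this core position, so the effect of an amine, a carboxylic acid or a longer chain there remains open. From the compounds shown here alone, whether the lower number seen with 2-(trifluoromethyl)phenyl carries over to the trifluoromethyl core also remains open.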